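The source may hold more compounds than are shown below. What is called first, only, known or untested is meant among the compounds shown, and "the series" means these compounds.

Measured so far:
- compound 1 `O=C(Nc1c(C(O)(C(F)(F)F)C(F)(F)F)ccc2ccccc12)C1CCC1`: 81.3 nM
- compound 2 `O=C(Nc1c(C(O)(C(F)(F)F)C(F)(F)F)ccc2ccccc12)c1cccc(Cl)c1`: 851 nM
- compound 3 `Cc1cccc(C(=O)Nc2c(C(O)(C(F)(F)F)C(F)(F)F)ccc3ccccc23)c1`: 52.5 nM

All three share one core and differ only in the group attached to the carbonyl carbon of the amide. In a functional assay (Sus scrofa) with sulfonylurea receptors; K-ATP channels (Homo sapiens) as the target (on this read-out higher numbers stand for an effect only at larger amounts of compound and lower numbers for an effect already at smaller amounts), compound 1 gives 81.3 nM, which places it second highest of the three numbers; its nearest neighbour is compound 3 with 52.5 nM, a gap within the scatter, while compound 2 with 851 nM lies furthest away.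

The step to compound 4 `O=C(Nc1c(C(O)(C(F)(F)F)C(F)(F)F)ccc2ccccc12)c1cccnc1` is pyridin-3-yl in place of cyclobutyl on a carbonyl carbon.

Within the data shown here, two measured steps bear on this, since both also exchange cyclobutyl for a six-membered aromatic ring: a 10-fold higher number from compound 1 to compound 2 (1.02 log units; beyond the scatter) and a 1.5-fold lower number from compound 1 to compound 3 (0.19 log units; within the scatter). They point in opposite directions, and the difference between them is itself large, as a 16-fold lower number from compound 2 to compound 3 (1.21 log units; beyond the scatter) shows; so an aromatic ring in this place can leave the number where it was or push it up markedly, depending on what the ring carries. Pyridin-3-yl carries no substituent but brings one hydrogen-bond acceptor into the ring, a feature neither compound 2 nor compound 3 has, so the measured steps give only loose guidance. The expectation is therefore a moderate rise with wide uncertainty: a 2.0-fold higher number from compound 1 to compound 4 (0.29 log units; within the scatter). Compound 4 is estimated at 160 nM, with a range from 35 nM to 900 nM.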

Compound 4, half-maximal effective concentration: 617 nM
Compound 4: middle estimate off by 3.9-fold (0.59 log units), on the low side; the range from low to high includes it.
By their numbers in this assay, from the lowest: compounds 3 and 1 (each within the scatter of the next); then compounds 4 and 2 (each within the scatter of the next).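

In this assay replacing cyclobutyl with pyridin-3-yl on the carbonyl carbon raises the number clearly (a 7.6-fold higher number from compound 1 to compound 4 (0.88 log units; beyond the scatter)). This shows that a high number at this position does not require a chloro group, since compound 4 has none. The pyridin-3-yl ring lands level with the 3-chlorophenyl ring within the scatter (a 1.4-fold lower number from compound 2 to compound 4 (0.14 log units; within the scatter)) and well apart from the 3-methylphenyl ring (a 12-fold higher number from compound 3 to compound 4 (1.07 log units; beyond the scatter)), so among the three aromatic rings shown, 3-methylphenyl alone stays close to cyclobutyl, and it is the exception to any rule that aromatic rings here raise the number. Nothing available explains why these rings behave so differently.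

The compounds shown leave open where a plain phenyl ring with no substituent would fall, and so whether the methyl group of compound 3 keeps the number low or the chloro group and the ring nitrogen each push it up. They also leave open how far the low numbers extend to other groups on the carbonyl carbon, such as cyclopentyl, a longer chain like butyl, or a ring carrying methoxy.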